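Chain extension at the ether oxygen: notes on compound 4

The source may report more compounds than this note shows. Statements on the series, on what has been measured and on what is new or still open speak of the compounds shown alone.

Compound 1 `CCC1(Cc2ccccc2)OS(=O)(=O)C=C1OCc1ccccc1Cl` has been examined in an ADME assay on HEL cells (Homo sapiens) for cytotoxicity, with a stated time of 3 days (a higher number here means that more compound is tolerated, a lower number that less compound is tolerated), where compound 1 gives 38000 nM. Within the data shown here, this is the lowest of the two numbers so far obtained; the nearest is compound 3 `CC(C)C1(Cc2ccccc2)OS(=O)(=O)C=C1OCc1ccccc1`, which in this assay gives 200000 nM, a gap that lies beyond the scatter. Compound 2 `CCC1(Cc2ccccc2)OS(=O)(=O)C=C1OC(c1ccccc1)c1ccccc1` reaches only a limit of this assay, > 200000 nM, and this is not a number. Thus the limit of > 200000 nM in this assay, at which 1 of the 3 values shown sits, marks the ceiling of what this assay can report in the series.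

Compound 4 `CCC1(Cc2ccccc2)OS(=O)(=O)C=C1OCCCc1ccccc1` has not yet been measured in this assay. It differs from compound 1 in one place: phenethyl in place of 2-chlorophenyl on a saturated chain carbon bound to an oxygen on an unsaturated carbon. Among the measured compounds shown here, no measured pair differs in only one place, so the step must be judged from the available values alone, with compound 1 standing apart from the two others that sit at or past the ceiling. A step toward a higher number is expected, a 2.6-fold higher number from compound 1 to compound 4 (0.42 log units; beyond the scatter), and the result may again end at the limit. For compound 4 the expected value in this assay is 100000 nM, with a range from 30000 nM to 200000 nM.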

Compound 4, half-maximal cytotoxic concentration: 133000 nM
The estimate for compound 4 lay 1.3-fold (0.12 log units) below the measured number, and the stated range covers the measured number.
By their numbers in this assay, from the lowest: compound 1; then compounds 4 and 3 (each within the scatter of the next).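

In this assay, the series now has its first readable step at this position, a 3.5-fold higher number from compound 1 to compound 4 (0.54 log units; beyond the scatter), which shows that the group on a saturated chain carbon bound to an oxygen on an unsaturated carbon can shift the tolerated concentration with the rest of the molecule held constant. Phenethyl and 2-chlorophenyl both carry one six-membered aromatic ring of carbon only, no hydrogen-bond donors or acceptors and no net charge, so this step pairs the loss of chlorine with a change in the chain, and this single pair cannot separate the two. Nothing measured here gives a reason for the step.

Still open is which part of the change, the loss of chlorine or the change in the chain, accounts for the step, a question that a chlorine-bearing phenethyl group would address directly. Also open, on these data alone, is how this assay responds at this position to a longer chain, or to an amine or a carboxylic acid at the end of the chain.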